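A few compounds are considered here, and "the series" means these few. Any claim that something is new, unique, unknown or untested is made for them only; others in the source may bear on it.

In an assay on CHO-K1 cells for displacement of a labelled ligand from adenosine receptor A1 (Homo sapiens), read by scintillation counting, with a stated time of 60 min (on this read-out lower numbers stand for stronger inhibition and higher numbers for weaker inhibition), compound 1 `Nc1nc(N/N=C/c2ccc3ncccc3c2)nc2c1ncn2[C@@H]1O[C@H](CO)[C@@H](O)[C@H]1O` gives 9.8 nM, and compound 2 `Nc1nc(N/N=C/c2cncs2)nc2c1ncn2[C@@H]1O[C@H](CO)[C@@H](O)[C@H]1O` gives 22 nM; the step of a 2.2-fold higher number from compound 1 to compound 2 (0.35 log units; beyond the scatter) is modest. Compound 3 `Nc1nc(N/N=C/c2ccc(Cl)c(C(F)(F)F)c2)nc2c1ncn2[C@@H]1O[C@H](CO)[C@@H](O)[C@H]1O` gives only a limit in this assay, > 10000 nM, which is the limit of > 10000 nM in this assay, at which 1 of the 3 values shown sits. Compound 3 therefore stands at the weak end of the three numbers shown, and the steps to it are large: an at least 1000-fold higher number from compound 1 to compound 3 (3.00 log units; beyond the scatter) and an at least 450-fold higher number from compound 2 to compound 3 (2.65 log units; beyond the scatter).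

Compound 4 `Nc1nc(N/N=C/C2CCCC2)nc2c1ncn2[C@@H]1O[C@H](CO)[C@@H](O)[C@H]1O` has not been measured in this assay. The change from compound 3 is cyclopentyl in place of 4-chloro-3-(trifluoromethyl)phenyl on a carbon with a double bond to nitrogen. Among the compounds with values here, no measured step replaces an aromatic ring on the carbon with a double bond to nitrogen by a non-aromatic one, so the two large steps show only that the 4-chloro-3-(trifluoromethyl)phenyl compound is the weak member; they do not fix where cyclopentyl lands. Since compound 3 is a limit, the expected step of an at least 10-fold lower number from compound 3 to compound 4 (1.00 log units; beyond the scatter) cannot be sized from its starting point, though a return toward measurable binding is expected. Compound 4 is estimated at 1000 nM, with a range from 100 nM to 10000 nM.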

Compound 4, inhibition constant: 5.6 nM
The estimate for compound 4 lay 180-fold (2.25 log units) above the measured number, outside the stated range (below it).
By their numbers in this assay, from the lowest: compounds 4 and 1 (each within the scatter of the next); then compound 2. At a limit, above all of these: compound 3.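

Cyclopentyl on the carbon with a double bond to nitrogen keeps binding in this assay, with a 3.9-fold lower number from compound 2 to compound 4 (0.59 log units; beyond the scatter) and a 1.8-fold lower number from compound 1 to compound 4 (0.24 log units; within the scatter), so an aromatic ring is not required at this place among the compounds shown. With quinolin-6-yl, 1,3-thiazol-5-yl and cyclopentyl all giving measured numbers, compound 3 is the only one of the four that goes against this, and its 4-chloro-3-(trifluoromethyl)phenyl, not aromatic rings as a class, marks the break. The largest change is an at least 1700-fold lower number from compound 3 to compound 4 (3.25 log units; beyond the scatter), and compound 3 is a limit: the limit of > 10000 nM in this assay, at which 1 of the 4 values shown sits.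

Whether the chlorine, the trifluoromethyl or the whole substituted phenyl accounts for compound 3 remains open. How an unsubstituted phenyl, a longer alkyl chain or an amine would behave at this place cannot be told from these compounds.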